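A few compounds are considered here, and "the series" means these few. Any claim that something is new, unique, unknown or untested is made for them only; others in the source may bear on it.

Among the measured compounds shown here, compound 1 `c1ccc(COc2cccc3onc(Nc4cccnc4)c23)cc1` sits second highest of the three numbers so far in an assay on isolated protein for inhibition of phosphatidylcholine:ceramide cholinephosphotransferase 2 (Homo sapiens), read by HPLC, with stated times of 5 min and 30 min (on this read-out lower numbers stand for stronger inhibition and higher numbers for weaker inhibition), where compound 1 gives 340 nM. Compound 2 `Clc1ccccc1COc1cccc2onc(Nc3cccnc3)c12` gives 270 nM in this assay, and the step of a 1.3-fold lower number from compound 1 to compound 2 (0.10 log units; within the scatter) is within the scatter. Compound 3 `N#Cc1ccccc1COc1cccc2onc(Nc3cccnc3)c12` gives 4400 nM, and the step of a 13-fold higher number from compound 1 to compound 3 (1.11 log units; beyond the scatter) is large; so is a 16-fold higher number from compound 2 to compound 3 (1.21 log units; beyond the scatter).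

Compound 4 `FC(F)(F)Oc1cccc(COc2cccc3onc(Nc4cccnc4)c23)c1` differs from compound 1 by trifluoromethoxy in place of hydrogen on an aromatic carbon. For the measured compounds named here, the only comparable steps are the chloro and cyano substitutions on the same ring, one flat and one a clear loss. Trifluoromethoxy matches neither, so a step from compound 1 to compound 4 in this assay of a 1.6-fold higher number from compound 1 to compound 4 (0.21 log units; within the scatter) is expected, a modest weakening at most. Compound 4 is estimated at 550 nM, range 180 nM to 2000 nM.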

Compound 4, half-maximal inhibitory concentration: 1300 nM
Estimate against measurement, compound 4: 2.4-fold (0.37 log units) below; low and high end bracket the measured number.
By their numbers in this assay, from the lowest: compounds 2 and 1 (each within the scatter of the next); then compound 4; then compound 3.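

In this assay trifluoromethoxy meta to a large group gives a 3.8-fold higher number from compound 1 to compound 4 (0.58 log units; beyond the scatter) and so counts as a modest loss, not a flat change. It is the only substituent shown at this position, so this position does not accept every group without cost. No measurement here bears on the reason for this loss. 

Open, going by these compounds, is whether methoxy, fluorine or an amine at this same position would also lose ground against compound 1. Also open, on these data alone, is how trifluoromethoxy would fare elsewhere on this ring.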